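Chain end changes, from compound 3 to compound 4

This account rests on a few compounds, and the source may have more. Where it says the series, first, only, none or still open, it means among the compounds named here.

Values in a functional assay on SEM cells (Homo sapiens) for cytotoxicity, with a stated time of 72 h (on this read-out higher numbers stand for an effect only at larger amounts of compound and lower numbers for an effect already at smaller amounts), each one a limit:
- compound 1 `C=C[C@@](C)(/C=C/c1ccc(O)cc1)CCC1OC1(C)C` gives > 36600 nM as a limit
- compound 2 `C=C[C@@](C)(/C=C/c1ccc(O)cc1)CC/C=C/C(=O)OCC` gives > 36600 nM as a limit
- compound 3 `C=C[C@@](C)(/C=C/c1ccc(O)cc1)CC/C=C(C)/C=N/N` gives > 36600 nM as a limit

Compound 3 has only a limit and no number, and the series stands as the limit of > 36600 nM in this assay, at which 3 of the 3 values shown sit, for now. Compound 4 `C=C[C@@](C)(/C=C/c1ccc(O)cc1)CC/C=C(C)/C=C/C(=O)OCC` follows from compound 3 by a group of 7 heavy atoms (5 carbon, 2 oxygen; no ring) in place of a group of 3 heavy atoms (1 carbon, 2 nitrogen; no ring), on a double-bonded chain carbon bound to a double-bonded chain carbon and a saturated chain carbon, which brings in 2-(ethoxycarbonyl)ethenyl. For the measured compounds named here, two measured steps touch that group, a step that the two limits leave unreadable from compound 1 to compound 2 and a step that the two limits leave unreadable from compound 2 to compound 3, and the third is a step that the two limits leave unreadable from compound 1 to compound 3 as well. None of them gives a size, so no step beyond the scatter is expected, in either direction. The expected change is a step that the limit leaves unreadable from compound 3 to compound 4 and it remains an estimate. Compound 4 is expected near 40000 nM with an estimated range of 20000 nM to 80000 nM and a limit is the likely report.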

Compound 4, half-maximal effective concentration: > 36600 nM
Compound 4 gave a limit, no number (the forecaster's own chance of this, stated with the estimate: 80%); the middle value does not contradict the limit.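

No step can be read from compound 3 to compound 4 in this assay, because both values are limits, as is the whole series: the limit of > 36600 nM in this assay, at which 4 of the 4 values shown sit.

The compounds shown leave open at what concentration compound 1, compound 2, compound 3 or compound 4 would show an effect in this assay.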